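The compounds below may be only part of what the source reports. "The series", "measured", "known", "first", "only" and "open" are said of these compounds alone.

Compound 2 `CC(C)(C)C(=O)OCO[P@@]1(=O)OCC(C)(C)[C@H](C(=O)NCCC(=O)OCc2cncs2)O1` stands at the short end of an ADME assay on blood (Homo sapiens) for pharmacokinetics; on this read-out higher numbers stand for a longer-lived compound and lower numbers for a shorter-lived compound: for compound 2 the < 0.16 h is a limit of the assay rather than a number (the limit of < 0.16 h in this assay, at which 1 of the 2 values shown sits). Compound 1 `CC(C)(C)C(=O)OCO[P@@]1(=O)OCC(C)(C)[C@H](C(=O)NCCC(=O)O)O1` gives > 1 h in this assay, which is also a limit (the limit of > 1 h in this assay, at which 1 of the 2 values shown sits). Within the data shown here, the one measured step, an at least 6.2-fold lower number from compound 1 to compound 2 (0.79 log units; beyond the scatter), sets the free acid against its ester. Among the measured compounds shown here, compound 3 `CC(C)(C)C(=O)OCO[P@@]1(=O)OCC(C)(C)[C@H](C(=O)NCCC(=O)OC2CCN(Cc3ccccc3)C2)O1` carries 1-benzylpyrrolidin-3-yl in place of (1,3-thiazol-5-yl)methyl on an oxygen next to a carbonyl group; compound 2 and compound 3 are both esters of the same acid, so no measured step bears directly on this swap. The expected step is a step that the limit leaves unreadable from compound 2 to compound 3, within the scatter. Compound 3 is therefore estimated at 0.12 h, range 0.05 h to 0.35 h.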

Compound 3, half-life: 0.19 h
Estimate against measurement, compound 3: 1.6-fold (0.20 log units) below, and the stated range covers the measured number.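

On the oxygen next to a carbonyl group, the short half-life is not confined to the (1,3-thiazol-5-yl)methyl ester: the 1-benzylpyrrolidin-3-yl ester also differs clearly from the free acid, with an at least 5.2-fold lower number from compound 1 to compound 3 (0.72 log units; beyond the scatter) in this assay. The swap between the two esters reads only as an at least 1.1-fold higher number from compound 2 to compound 3 (0.07 log units; that floor lies within the scatter); its starting value is a limit of the assay, and the two esters stay unordered.

Open, from the compounds shown here alone, is whether a simple ethyl ester or an amide at this place would behave alike. Going by these compounds, compound 1 gives > 1 h, which is a limit, and the full size of its steps stays open.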